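The compounds below may be only part of what the source reports. "The series", "measured", "known", "first", "only" and "open" are said of these compounds alone.

Measured so far:
- compound 1, `CC[C@@H](C1CC1)n1c(=O)c(C)nc2c(-c3ccc(Cl)cc3Cl)nccc21` — 55 nM in a functional assay for antagonist activity at corticotropin-releasing factor receptor 1 (Rattus norvegicus); a lower number here means a stronger inhibitor, a higher number a weaker inhibitor
- compound 2, `CC[C@H](COC)n1c(=O)c(C)nc2c(-c3ccc(Cl)cc3Cl)ncnc21` — in this assay compound 2 gives 97 nM

Compound 2 holds the highest of the two numbers, but its nearest neighbour is compound 1, and that gap is within the usual scatter of this assay, so the two are not separable on the numbers. Going by the values given here, compound 1 and compound 2 differ in two places at once, on the shared core and on the side chain carried by the aromatic nitrogen, so no single-change step between measured compounds is available.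

Compound 3, `CC[C@@H](C1CC1)n1c(=O)c(C)nc2c(-c3ccc(Cl)cc3Cl)ncnc21`, takes the core of compound 2 and carries the side chain of compound 1: 1-cyclopropylpropyl in place of 1-(methoxymethyl)propyl on an aromatic nitrogen. Among the compounds with values here, both measured compounds sit close together, and the side chain entering here is the one present in compound 1, which gives 55 nM. The step from compound 2 to compound 3 is therefore expected to be small, at most a modest move toward a lower number, and quite possibly none beyond the scatter; the expected step is a 1.6-fold lower number from compound 2 to compound 3 (0.21 log units; within the scatter). Compound 3 is estimated at 60 nM, with a range from 20 nM to 180 nM.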

Compound 3, half-maximal inhibitory concentration: 24 nM
Compound 3: middle estimate off by 2.5-fold (0.40 log units), on the high side, and the stated range covers the measured number.
By their numbers in this assay, from the lowest: compound 3; then compounds 1 and 2 (each within the scatter of the next).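

On the core shared by compound 2 and compound 3, 1-cyclopropylpropyl in place of 1-(methoxymethyl)propyl on the aromatic nitrogen gives, in this assay, a 4.0-fold lower number from compound 2 to compound 3 (0.61 log units; beyond the scatter). Going by these compounds alone, this is the first single-place reading, and it shows that the side chain at this position can shift the number beyond the scatter, which the earlier pair, differing in two places at once, could not show. The change keeps the side chain at 6 heavy atoms while it removes the ether oxygen and brings in a three-membered carbon ring, and no measurement shown gives a reason for the step.

With the loss of the oxygen and the gain of the ring arriving together, the step cannot yet be assigned to either one; a side chain with neither, such as 1-ethylbutyl, or one with a cyclobutyl ring in place of the cyclopropyl ring, would begin to separate them. Also open is whether the same side-chain change gives a similar step on the core of compound 1, where the 1-(methoxymethyl)propyl partner is not among the compounds shown.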